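Propyl to 2-methylphenyl: a step within the scatter expected

The source may report more compounds than this note shows. Statements on the series, on what has been measured and on what is new or still open speak of the compounds shown alone.

Three measured compounds share one core and differ only in the group on a saturated chain carbon bound to an aromatic nitrogen. Compound 3 `CCCCn1cc(COc2cc(O)c3c(c2)O[C@H](c2ccc(OC)c(O)c2)CC3=O)nn1` carries propyl there; in a functional assay on RAW264.7 cells (Mus musculus) for inhibition, read by Griess assay, with stated times of 2 h and 24 h (a lower number here means a stronger inhibitor, a higher number a weaker inhibitor), compound 3 gives 13900 nM, the lowest of the three numbers shown, yet all three lie within the scatter of one another: compound 1 `COc1ccc([C@@H]2CC(=O)c3c(O)cc(OCc4cn(Cc5ccccc5C#N)nn4)cc3O2)cc1O` gives 14600 nM and compound 2 `COc1ccc([C@@H]2CC(=O)c3c(O)cc(OCc4cn(Cc5ccc(C)cc5)nn4)cc3O2)cc1O` gives 16800 nM, so that a 1.1-fold lower number from compound 1 to compound 3 (0.02 log units; within the scatter) and a 1.2-fold lower number from compound 2 to compound 3 (0.08 log units; within the scatter). Compound 4 `COc1ccc([C@@H]2CC(=O)c3c(O)cc(OCc4cn(Cc5ccccc5C)nn4)cc3O2)cc1O` is not yet measured; its change is 2-methylphenyl in place of propyl on a saturated chain carbon bound to an aromatic nitrogen. Among the measured compounds shown here, the steps that bear on it, including a 1.2-fold higher number from compound 1 to compound 2 (0.06 log units; within the scatter), were all within the scatter whether 2-cyanophenyl, 4-methylphenyl or propyl stood at this place, so no step beyond the scatter is expected: a 1.0-fold higher number from compound 3 to compound 4 (0.00 log units; within the scatter). For compound 4 the estimated value is 14000 nM, with a range from 7000 nM to 28000 nM.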

Compound 4, half-maximal inhibitory concentration: 13100 nM
The estimate for compound 4 lay 1.1-fold (0.03 log units) above the measured number; measured number inside the range.
By their numbers in this assay, from the lowest: compounds 4, 3, 1 and 2 (each within the scatter of the next).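

In this assay, an aromatic ring in place of an open chain at this place changes little: 2-methylphenyl in place of propyl gives a 1.1-fold lower number from compound 3 to compound 4 (0.03 log units; within the scatter). The ring's substituent matters just as little, with 2-methylphenyl in place of 4-methylphenyl giving a 1.3-fold lower number from compound 2 to compound 4 (0.11 log units; within the scatter) and methyl in place of cyano giving a 1.1-fold lower number from compound 1 to compound 4 (0.05 log units; within the scatter). No measurement at hand explains why these steps are so small.

As far as these compounds go, it remains open whether an amine or a carboxylic acid at this place, or a much longer chain, would give a step beyond the scatter.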